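The source may report more compounds than this note shows. Statements on the series, on what has been measured and on what is new or still open speak of the compounds shown alone.

In an ADME assay (liver) for metabolic stability, with Liver microsome (Rattus norvegicus) as the target, using microsomes and NADPH, with a stated time of 30 min, tested at 1 uM (on this read-out higher numbers stand for fast clearance and lower numbers for slow clearance), three compounds sharing one core have been measured. Compound 1 `COc1cc(C(O)(C(F)(F)F)C(F)(F)F)cnc1N1CCN(S(=O)(=O)c2ccc(N)nc2)CC1`, which carries a methoxy group, reports < 14 mL.min-1.g-1, and this is a limit of the assay, not a number. Compound 2 `COCC#Cc1cc(C(O)(C(F)(F)F)C(F)(F)F)cnc1N1CCN(S(=O)(=O)c2ccc(N)nc2)CC1` gives 399 mL.min-1.g-1. Compound 3 `Nc1ccc(S(=O)(=O)N2CCN(c3ncc(C(O)(C(F)(F)F)C(F)(F)F)cc3C#CCCO)CC2)cn1` gives 68 mL.min-1.g-1, the lower of the two actual numbers. Compound 4 `Cn1cc(-c2cc(C(O)(C(F)(F)F)C(F)(F)F)cnc2N2CCN(S(=O)(=O)c3ccc(N)nc3)CC2)cn1` has 1-methyl-1H-pyrazol-4-yl in place of the 4-hydroxybut-1-yn-1-yl of compound 3 on an aromatic carbon: 1-methyl-1H-pyrazol-4-yl in place of 4-hydroxybut-1-yn-1-yl on an aromatic carbon. The closest evidence comes from changes at that same carbon. Replacing methoxy there raised the number in both cases, a large change in an at least 28-fold higher number from compound 1 to compound 2 (1.45 log units; beyond the scatter) and a smaller one in an at least 4.8-fold higher number from compound 1 to compound 3 (0.68 log units; beyond the scatter). Changing only the end of the chain gave a modest step, a 5.9-fold lower number from compound 2 to compound 3 (0.77 log units; beyond the scatter). None of these steps involves a pyrazole, so no clear change is expected in this assay, and the estimate is a 1.2-fold higher number from compound 3 to compound 4 (0.07 log units; within the scatter). The expected value for compound 4 is 80 mL.min-1.g-1, within an estimated range of 25 mL.min-1.g-1 to 250 mL.min-1.g-1.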

Compound 4, intrinsic clearance in microsomes: 44 mL.min-1.g-1
Estimate against measurement, compound 4: 1.8-fold (0.26 log units) above, and the stated range covers the measured number.
By their numbers in this assay, from the lowest: compounds 4 and 3 (each within the scatter of the next); then compound 2. At a limit, below all of these: compound 1.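

In this assay, a five-membered aromatic ring at this carbon reads the same as a chain with a triple bond and a hydroxyl end, with a 1.5-fold lower number from compound 3 to compound 4 (0.19 log units; within the scatter). The same ring stands clearly apart from the chain ending in a methoxy group, with a 9.1-fold lower number from compound 2 to compound 4 (0.96 log units; beyond the scatter), so the number of compound 2 is not shared by the other two larger groups at this carbon. Putting the ring in place of methoxy gives an at least 3.1-fold higher number from compound 1 to compound 4 (0.49 log units; beyond the scatter), a step that rests on the value of compound 1, which is a limit of the assay and not a number: the limit of < 14 mL.min-1.g-1 in this assay, at which 1 of the 4 values shown sits.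

Still open, going by these compounds, is how a phenyl ring, an amine or a carboxylic acid would read at this carbon. With a single ring shown, it also stays unclear whether the methyl group on the pyrazole matters to this number.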